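Pyrrolidin-1-yl in place of piperidin-1-yl

The compounds below may be only part of what the source reports. "The series", "measured", "known", "first", "only" and "open" are said of these compounds alone.

Measured so far in an ADME assay on L6 cells (Rattus norvegicus) for cytotoxicity, with a stated time of 72 h; on this read-out lower numbers stand for stronger inhibition and higher numbers for weaker inhibition:
Compound 1 `CCN(CC)CC(=O)OC1CC2(N3CCCC3)CC(c3ccccc3)C1C(c1ccccc1)C2` gives 49000 nM
Compound 2 `O=C(CN1CCCCC1)OC1CC2(N3CCCC3)CC(c3ccccc3)C1C(c1ccccc1)C2` gives 14200 nM

Compound 2 stands lowest of the two measured compounds with 14200 nM on this read-out. Within the data shown here, the one measured step that bears on the next change is a 3.5-fold lower number from compound 1 to compound 2 (0.54 log units; beyond the scatter) and it is modest, with piperidin-1-yl taking the place of diethylamino on a saturated chain carbon bound to a carbonyl carbon. Compound 3 `O=C(CN1CCCC1)OC1CC2(N3CCCC3)CC(c3ccccc3)C1C(c1ccccc1)C2` keeps the shared core and differs from compound 2 at that same place, with pyrrolidin-1-yl in place of piperidin-1-yl on a saturated chain carbon bound to a carbonyl carbon and nothing else changes. The earlier step exchanged diethylamino for a ring, whereas here one non-aromatic ring replaces another, so a smaller move than a 3.5-fold lower number from compound 1 to compound 2 (0.54 log units; beyond the scatter) is expected, with only a slight lean towards a higher number. The estimated step is a 1.3-fold higher number from compound 2 to compound 3 (0.10 log units; within the scatter) and it is expected to stay within the scatter. For compound 3 the estimated value in this assay is 18000 nM with an expected range from 8000 nM to 42000 nM on this read-out.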

Compound 3, half-maximal inhibitory concentration: 42900 nM
The estimate for compound 3 lay 2.4-fold (0.38 log units) below the measured number, outside the stated range (above it).
By their numbers in this assay, from the lowest: compound 2; then compounds 3 and 1 (each within the scatter of the next).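

In this assay, the change from the six-membered to the five-membered non-aromatic ring on a saturated chain carbon bound to a carbonyl carbon gives a 3.0-fold higher number from compound 2 to compound 3 (0.48 log units; beyond the scatter) and is not the quiet swap of one ring for another that it might appear to be. Among these compounds, it also shows that having a ring at this place does not by itself go with the lower number, since the pyrrolidin-1-yl of compound 3 and the diethylamino of compound 1 remain within the scatter of each other, at a 1.1-fold lower number from compound 1 to compound 3 (0.06 log units; within the scatter), leaving the piperidin-1-yl of compound 2 as the only group of the three that stands apart. Nothing available here explains why the five-membered and six-membered rings differ at this place.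

The compounds shown leave open whether the lower number belongs to piperidin-1-yl alone or would also appear with another ring at this place, such as azepan-1-yl or morpholin-4-yl. They also leave open whether the same ring swap would give a step of similar size with a longer chain between the carbonyl and the ring nitrogen.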